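Working notes: aryl change on the sulfonyl sulfur

The source may hold more compounds than are shown below. What is called first, only, known or untested is meant among the compounds shown, and "the series" means these compounds.

- compound 1 `CC(O)(COc1ccc(OC(F)(F)F)cc1)C(=O)Nc1ccc(S(F)(F)(F)(F)F)cc1` in a functional assay on CWR22R cells (Homo sapiens) for antiproliferative activity, read by propidium iodide staining, with a stated time of 96 h (a lower number here means a stronger inhibitor, a higher number a weaker inhibitor), gives 27900 nM
- compound 2 `CC(O)(CS(=O)(=O)c1ccc(F)cc1)C(=O)Nc1ccc(S(F)(F)(F)(F)F)cc1` in this assay gives 20600 nM

Compound 2 and compound 1 lie within the scatter of each other, so neither stands apart on these two numbers. Compound 3 `CC(O)(CS(=O)(=O)c1ccccc1C(F)(F)F)C(=O)Nc1ccc(S(F)(F)(F)(F)F)cc1` carries the change 2-(trifluoromethyl)phenyl in place of 4-fluorophenyl on a sulfonyl sulfur with 2-(trifluoromethyl)phenyl in place of 4-fluorophenyl on a sulfonyl sulfur. Going by the values given here, no measured step covers this change, so no step beyond the scatter is expected in this assay and no direction is favoured. The expected step is a 1.1-fold lower number from compound 2 to compound 3 (0.06 log units; within the scatter) (an estimate only). The estimated value for compound 3 is 18000 nM (range 7000 nM to 40000 nM).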

Compound 3, half-maximal inhibitory concentration: 17400 nM
Compound 3: middle estimate off by 1.0-fold (0.01 log units), on the high side, and the stated range covers the measured number.
By their numbers in this assay, from the lowest: compounds 3, 2 and 1 (each within the scatter of the next).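

On the sulfonyl sulfur, 2-(trifluoromethyl)phenyl in place of 4-fluorophenyl gives a 1.2-fold lower number from compound 2 to compound 3 (0.07 log units; within the scatter) in this assay, the only single-place step shown in the series. At this position, the swap to the group with more heavy atoms leaves the number within the scatter. Nothing measured bears on why the two aryl groups read alike.

Still open, going by these compounds, is whether an amine or a carboxylic acid on the phenyl ring, or a longer chain in place of the aryl group on the sulfonyl sulfur, would move the number beyond the scatter.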